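This account rests on a few compounds, and the source may have more. Where it says the series, first, only, none or still open, it means among the compounds named here.

In a functional assay on HeLa cells (Homo sapiens) for antiproliferative activity, read by sulforhodamine B assay, with a stated time of 48 h (on this read-out higher numbers stand for weaker inhibition of growth and lower numbers for stronger inhibition of growth), three compounds have been measured:
compound 1, `O=C(NCc1cn(Cc2ccc(Cl)cc2)nn1)c1cn(-c2ccccc2)nc1-c1ccccc1`, 600 nM;
compound 2, `O=C(NCc1cn(Cc2ccc(C(F)(F)F)cc2)nn1)c1cn(-c2ccccc2)nc1-c1ccccc1`, 1600 nM;
compound 3, `O=C(NCc1cn(Cc2ccc(Cl)cc2)nn1)c1cn(-c2ccccc2)nc1-c1ccc(Cl)cc1`, 470 nM.

Compound 4, `O=C(NCc1cn(Cc2ccc(C(F)(F)F)cc2)nn1)c1cn(-c2ccccc2)nc1-c1ccc(Cl)cc1`, has not yet been measured in this assay. Compound 1 and compound 3 differ only in the core, by chloro in place of hydrogen on an aromatic carbon, a change that gave a 1.3-fold lower number from compound 1 to compound 3 (0.11 log units; within the scatter). Going from compound 1 to compound 2, the change trifluoromethyl in place of chloro on an aromatic carbon gave a 2.7-fold higher number from compound 1 to compound 2 (0.43 log units; beyond the scatter). The same change at the same place is made from compound 3 to compound 4: trifluoromethyl in place of chloro on an aromatic carbon. Because a 2.7-fold higher number from compound 1 to compound 2 (0.43 log units; beyond the scatter), compound 4 is expected to show a step of similar size, namely a 2.8-fold higher number from compound 3 to compound 4 (0.44 log units; beyond the scatter). Compound 4 is therefore estimated at 1300 nM in this assay, most likely falling between 600 nM and 2800 nM.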

Compound 4, concentration for 50% growth inhibition: 1900 nM
Beside the measured number, compound 4's estimate is 1.5-fold (0.16 log units) below it; the range from low to high includes it.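

In this assay, trifluoromethyl in place of chloro on an aromatic carbon gave a 4.0-fold higher number from compound 3 to compound 4 (0.61 log units; beyond the scatter), and this step carried over from one core to the other with no difference beyond the scatter: the same change on two cores in this assay, a 2.7-fold higher number (0.43 log units; beyond the scatter) from compound 1 to compound 2 and a 4.0-fold higher number (0.61 log units; beyond the scatter) from compound 3 to compound 4, 1.5-fold (0.18 log units) apart, within the scatter of two such steps. Chloro in place of hydrogen on an aromatic carbon gave a 1.2-fold higher number from compound 2 to compound 4 (0.07 log units; within the scatter), a step that likewise reads alike on both cores: the same change on two cores in this assay, a 1.3-fold lower number (0.11 log units; within the scatter) from compound 1 to compound 3 and a 1.2-fold higher number (0.07 log units; within the scatter) from compound 2 to compound 4, 1.5-fold (0.18 log units) apart, within the scatter of two such steps. This shows that each change behaved alike across these four compounds only; it does not show that either change would carry over to any other core, and it does not explain the steps.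

The compounds shown leave open how a methoxy group, an amine or a carboxylic acid in place of the chloro of the 4-chlorobenzyl group would read in this assay.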